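The source may hold more compounds than are shown below. What is called first, only, known or untested is meant among the compounds shown, and "the series" means these compounds.

Measured in a physicochemical assay for solubility, read by HPLC, in phosphate buffer, with a stated time of 16 h, at pH 6.8; a lower number here means a less soluble compound, a higher number a more soluble compound:
Compound 1 `Cc1ccc([C@H](C)NC(=O)Cn2nnc3ccccc3c2=O)c(F)c1`: 4500 nM
Compound 2 `COc1ccc2nnn(CC(=O)N[C@@H](C)c3ccc(C)cc3)c(=O)c2c1`: 2300 nM

Of the compounds shown here, two have been measured so far. Compound 2, at 2300 nM, lies within the usual scatter of compound 1, at 4500 nM, so this assay does not separate them. Going by the values given here, the two also differ in more than one place, which means that no measured step speaks directly to the next comparison.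

That comparison is with compound 3 `Cc1ccc([C@H](C)NC(=O)Cn2nnc3ccc(C(F)(F)F)cc3c2=O)cc1`, which is still unmeasured. It carries trifluoromethyl in place of methoxy on an aromatic carbon, on a six-membered aromatic ring of carbon only that is part of a fused or bridged system of two rings. The rest of the structure is the same as in compound 2.

Among the compounds with values here, with no measured precedent for this exchange, the expectation is uncertain. A modest fall in this assay is expected, only a little beyond the scatter, and is estimated as a 2.3-fold lower number from compound 2 to compound 3 (0.36 log units; beyond the scatter). For compound 3 the expected value is 1000 nM, with an estimated range from 300 nM to 3000 nM.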

Compound 3, solubility: 6600 nM
The estimate for compound 3 lay 6.6-fold (0.82 log units) below the measured number, and the stated range ends below it.
By their numbers in this assay, from the lowest: compounds 2, 1 and 3 (each within the scatter of the next, the first and the last beyond it).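

In this assay, going by these compounds alone, the exchange of methoxy for trifluoromethyl, on an aromatic carbon that is meta to a fused ring and para to a fused ring, gives a 2.9-fold higher number from compound 2 to compound 3 (0.46 log units; beyond the scatter) and is the first change in this set that can be read at a single place. It shows that at this carbon, replacing a group of 2 heavy atoms and 1 hydrogen-bond acceptor with one of 4 heavy atoms and no hydrogen-bond acceptor raised the number modestly rather than lowering it, with the rest of the structure unchanged. No measurement shown accounts for this rise.

Going by these compounds, whether the rise is particular to trifluoromethyl, or would also appear with another group on this carbon, such as a chlorine atom, a nitrile or an amine, remains open. The step also rests on a single pair, so it is not yet known whether the same exchange would give a similar step with the fluorine-bearing aromatic ring of compound 1 in the structure.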